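Boronic chalcone series: aryl ketone variation, compound 3 estimate

The compounds below may be only part of what the source reports. "The series", "measured", "known", "first", "only" and "open" are said of these compounds alone.

Compound 2 `Nc1ccc(C(=O)/C=C/c2ccc3c(c2)B(O)OC3)cc1` gives the lowest of the two numbers in a functional assay on SK-OV-3 cells (Homo sapiens) for cytotoxicity, read by MTT assay, with a stated time of 48 h (on this read-out lower numbers stand for stronger inhibition and higher numbers for weaker inhibition), at 20200 nM; compound 1 `Cn1cccc1C(=O)/C=C/c1ccc2c(c1)B(O)OC2` gives 93600 nM. For the measured compounds named here, the one measured step, a 4.6-fold lower number from compound 1 to compound 2 (0.67 log units; beyond the scatter), concerns a different aryl exchange on the carbonyl carbon. Compound 3 `O=C(/C=C/c1ccc2c(c1)B(O)OC2)c1cccc(F)c1` carries 3-fluorophenyl in place of 4-aminophenyl on a carbonyl carbon. Going by the values given here, no measured step bears directly on this change, so only a weak or uncertain shift in this assay can be anticipated. Compound 3 is expected to give 40000 nM, within 15000 nM to 120000 nM. This expectation corresponds to an estimated step of a 2.0-fold higher number from compound 2 to compound 3 (0.30 log units; within the scatter).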

Compound 3, half-maximal inhibitory concentration: 4800 nM
Compound 3: the middle estimate sits 8.3-fold (0.92 log units) above what was measured; measured number outside the range, below it.
By their numbers in this assay, from the lowest: compound 3; then compound 2; then compound 1.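

Exchange on the carbonyl carbon reaches further than compound 2 suggested: in this assay there is a 4.2-fold lower number from compound 2 to compound 3 (0.62 log units; beyond the scatter) with 3-fluorophenyl in place of 4-aminophenyl, and a 20-fold lower number from compound 1 to compound 3 (1.29 log units; beyond the scatter) with 3-fluorophenyl in place of 1-methyl-1H-pyrrol-2-yl. The lowest number of the three therefore needs no hydrogen-bond donor or acceptor on this aryl group. No evidence on hand gives a cause for these shifts. On these data alone, how far the fluorine and the loss of the amine each count stays open. An unsubstituted phenyl or a 3-aminophenyl on the same carbonyl carbon would separate the two.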